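Swapping chloro for methyl at the assay limit

The source may hold more compounds than are shown below. What is called first, only, known or untested is meant among the compounds shown, and "the series" means these compounds.

In an ADME assay on 2209-23 cells (Homo sapiens) for cytotoxicity, read by WST assay and thymidine incorporation (a higher number here means that more compound is tolerated, a lower number that less compound is tolerated), compound 3 `CC(C)(C)[C@H]1C(O)=C(C2=C(Cl)S(=O)(=O)c3cc(NS(C)(=O)=O)ccc3N2)C(=O)N1Cc1ccc(F)cc1` gives > 50000 nM, which is a limit of the assay and not a number. Compound 1 `CC(=O)C1=C(C2=C(O)[C@H](C(C)(C)C)N(Cc3ccc(F)cc3)C2=O)Nc2ccc(NS(C)(=O)=O)cc2S1(=O)=O` gives > 50000 nM, also a limit. Compound 2 `CC(C)(C)[C@H]1C(O)=C(C2=CS(=O)(=O)c3cc(NS(C)(=O)=O)ccc3N2)C(=O)N1Cc1ccc(F)cc1` gives > 50000 nM, again a limit. The whole picture so far is therefore (the limit of > 50000 nM in this assay, at which 3 of the 3 values shown sit).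

Compound 4 `CC1=C(C2=C(O)[C@H](C(C)(C)C)N(Cc3ccc(F)cc3)C2=O)Nc2ccc(NS(C)(=O)=O)cc2S1(=O)=O` differs from compound 3 by methyl in place of chloro on a double-bonded ring carbon. Three measured changes bear on this, all on that same kind of carbon: a step that the two limits leave unreadable from compound 1 to compound 2, a step that the two limits leave unreadable from compound 1 to compound 3 and a step that the two limits leave unreadable from compound 2 to compound 3. With acetyl, hydrogen or chloro there, the reading stays at the limit, so none of these steps has a size to carry over.

Going by a step that the two limits leave unreadable from compound 2 to compound 3, no step beyond the usual scatter is expected in this assay. The expected change is a number no higher from compound 3 to compound 4 (the limit leaves the size open). For compound 4 the estimate is 50000 nM, with an expected range from 30000 nM to 100000 nM, and most likely the assay will again report only a limit.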

Compound 4, half-maximal cytotoxic concentration: > 50000 nM
Compound 4: only a limit was reported; the forecaster's own chance of this, stated with the estimate: 85%; the middle value sits exactly at the limit.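

Compound 4 gives > 50000 nM in this assay, again a limit and not a number, so the steps to it from compound 1, compound 2 and compound 3 cannot be read. Whether acetyl, hydrogen, chloro or methyl on that double-bonded ring carbon makes any difference to the tolerated concentration stays open, with every compound shown at the same reading: the limit of > 50000 nM in this assay, at which 4 of the 4 values shown sit.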